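The source may hold more compounds than are shown below. What is called first, only, known or untested is meant among the compounds shown, and "the series" means these compounds.

Measured compounds in an ADME assay on microsomes from liver (Homo sapiens) for metabolic stability, tested at 2.5 uM; a higher number here means faster removal of the compound, a lower number slower removal:
- compound 1 `O=S(=O)(c1ccc(F)c(F)c1)c1cnc2cc(F)ccc2c1-c1ccc(Cl)cc1` gives 0.01 mL/min
- compound 2 `COc1ccc(S(=O)(=O)c2cnc3cc(F)ccc3c2-c2cccc(F)c2)cc1Cl` gives 2.08 mL/min
- compound 3 `COc1ccc(S(=O)(=O)c2cnc3cc(F)ccc3c2-c2cccc(F)c2)cc1` gives 2.94 mL/min

Compound 3 has the highest number of the three in this assay; compound 2 is the nearest, and the two lie within the scatter of each other, so no order between them is claimed. Compound 1 stands far lower, beyond the scatter.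

Compound 4 `O=S(=O)(c1ccc(F)c(F)c1)c1cnc2cc(F)ccc2c1-c1cccc(F)c1` is not yet measured. Its change from compound 3 is 3,4-difluorophenyl in place of 4-methoxyphenyl on a sulfonyl sulfur. Among the measured compounds shown here, the only measured step, a 1.4-fold higher number from compound 2 to compound 3 (0.15 log units; within the scatter), concerns the chloro group and does not touch the sulfonyl aryl, so it gives no guide here. For the measured compounds named here, no measured pair differs only in this way. Compound 1, which carries the same 3,4-difluorophenyl on the sulfonyl sulfur, gives 0.01 mL/min, but compound 1 also differs from compound 4 in the other aryl group, so its number bears only loosely on the step.

Compound 4 is expected to show a lower number than compound 3, by about a 9.8-fold lower number from compound 3 to compound 4 (0.99 log units; beyond the scatter), with wide uncertainty. The estimate for compound 4 in this assay is 0.3 mL/min, ranging from 0.03 mL/min to 2 mL/min.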

Compound 4, intrinsic clearance in a liver preparation (reported as CLH), per the amount of preparation that the assay uses: 0.6 mL/min
Beside the measured number, compound 4's estimate is 2.0-fold (0.30 log units) below it; the measured number falls inside the stated range.
By their numbers in this assay, from the lowest: compound 1; then compound 4; then compounds 2 and 3 (each within the scatter of the next).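

In this assay, among the compounds shown here, 3,4-difluorophenyl in place of 4-methoxyphenyl on a sulfonyl sulfur gives a 4.9-fold lower number from compound 3 to compound 4 (0.69 log units; beyond the scatter) and 3,4-difluorophenyl in place of 3-chloro-4-methoxyphenyl gives a 3.5-fold lower number from compound 2 to compound 4 (0.54 log units; beyond the scatter) as the first direct readings of a change at this position, both modest. The other aryl group moves the number further: 3-fluorophenyl in place of 4-chlorophenyl on an aromatic carbon gives a 60-fold higher number from compound 1 to compound 4 (1.78 log units; beyond the scatter) in this assay, a large step, so the 3,4-difluorophenyl group alone does not carry the very low number of compound 1. No supporting evidence bears on the reason for these steps.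

The compounds shown leave open how the sulfonyl position responds to an amine, a carboxylic acid or a longer alkyl chain in place of these aryl groups. As far as these compounds go, whether the large step holds with 4-methoxyphenyl on the sulfonyl sulfur also remains open.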